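A few compounds are considered here, and "the series" means these few. Any claim that something is new, unique, unknown or untested is made for them only; others in the source may bear on it.

Measured so far:
Compound 1, `C=CC1=C(C(=O)NC(C)(C)C)C(c2ccc(OC)cc2)OC1`, gives in a functional assay on A549 cells (Homo sapiens) for cytotoxicity, read by MTT assay, with a stated time of 24 h (on this read-out higher numbers stand for weaker inhibition and lower numbers for stronger inhibition), the value > 100000 nM, a limit of the assay.
Compound 2, `C=CC1=C(C(=O)NCc2ccc(Cl)cc2)C(c2ccc(F)cc2)OC1`, gives in this assay the value > 100000 nM, again only a limit.
Compound 3, `C=CC1=C(C(=O)Nc2ccc(OCC)cc2)C(c2ccc(OC)cc2)OC1`, gives in this assay the value 17600 nM.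

Compound 2 thus sits at the limit of > 100000 nM in this assay, at which 2 of the 3 values shown sit, where no number was reached. Among the compounds with values here, only one step connects measured compounds: an at least 5.6-fold lower number from compound 1 to compound 3 (0.75 log units; beyond the scatter), in which an aryl group replaces tert-butyl on the amide-type nitrogen. Compound 4, `C=CC1=C(C(=O)NC(C)(C)C)C(c2ccc(F)cc2)OC1`, differs from compound 2 by a change of the opposite kind, (tert-butyl in place of 4-chlorobenzyl on an amide-type nitrogen). As compound 1 with tert-butyl in that place gives > 100000 nM, compound 4 is expected to remain at the limit, with a number no higher from compound 2 to compound 4 (the limit leaves the size open) meaning no detectable change. The estimate for compound 4 in this assay is 100000 nM, within 30000 nM to 300000 nM.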

Compound 4, half-maximal inhibitory concentration: > 100000 nM
Compound 4 gave a limit, no number; the forecaster's own chance of this, stated with the estimate: 80%; the middle value sits exactly at the limit.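

Compound 1, compound 2 and compound 4 all sit at a limit of the assay, and the steps to compound 4 from compound 1 and from compound 2 cannot be read. As far as these compounds go, whether tert-butyl versus 4-chlorobenzyl on the amide-type nitrogen, or fluoro versus methoxy on the aromatic carbon, makes any difference stays open.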